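Swapping the amide aryl group in a flavonol antiproliferative series

This account rests on a few compounds, and the source may have more. Where it says the series, first, only, none or still open, it means among the compounds named here.

Measured compounds:
compound 1, `O=C(Nc1cccc(-c2oc3cc(-c4ccc(F)cc4)ccc3c(=O)c2O)c1)c1ccc(F)cc1`, 8590 nM
compound 2, `O=C(Nc1cccc(-c2oc3cc(-c4ccc(F)cc4)ccc3c(=O)c2O)c1)c1ccc(F)cc1F`, 13500 nM
compound 3, `Cc1ccccc1C(=O)Nc1cccc(-c2oc3cc(-c4ccc(F)cc4)ccc3c(=O)c2O)c1`, 2280 nM

The three compounds share one core and differ only in the aryl group attached to the amide carbonyl. In a functional assay on MCF7 cells (Homo sapiens) for antiproliferative activity, read by CCK-8 assay, with a stated time of 72 h (on this read-out lower numbers stand for stronger inhibition and higher numbers for weaker inhibition), compound 1 gives 8590 nM, compound 2 gives 13500 nM and compound 3 gives 2280 nM. Compound 3 stands lowest of the three: the step of a 3.8-fold lower number from compound 1 to compound 3 (0.58 log units; beyond the scatter) and the step of a 5.9-fold lower number from compound 2 to compound 3 (0.77 log units; beyond the scatter) both lie beyond the scatter, while a 1.6-fold higher number from compound 1 to compound 2 (0.20 log units; within the scatter) does not.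

Compound 4, `O=C(Nc1cccc(-c2oc3cc(-c4ccc(F)cc4)ccc3c(=O)c2O)c1)c1ccc(Cl)nc1`, has not yet been measured in this assay. Relative to compound 3 the change is 6-chloropyridin-3-yl in place of 2-methylphenyl on a carbonyl carbon. For the measured compounds named here, the steps that bear on this change are those from compound 1 and compound 2 to compound 3, which show that exchanging an aryl group on the carbonyl carbon can move the number by a modest amount, and that the 2-methylphenyl compound gave the lowest number. Since compound 4 gives up that group, a modest step back toward the higher numbers of compound 1 and compound 2 is expected, a 2.6-fold higher number from compound 3 to compound 4 (0.42 log units; beyond the scatter). Compound 4 is therefore estimated at 6000 nM, within the range 2500 nM to 15000 nM.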

Compound 4, half-maximal inhibitory concentration: 2890 nM
The estimate for compound 4 lay 2.1-fold (0.32 log units) above the measured number, and the stated range covers the measured number.
By their numbers in this assay, from the lowest: compounds 3 and 4 (each within the scatter of the next); then compounds 1 and 2 (each within the scatter of the next).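

With a 1.3-fold higher number from compound 3 to compound 4 (0.10 log units; within the scatter) in this assay the exchange of 2-methylphenyl for 6-chloropyridin-3-yl on the carbonyl carbon moves the number by no more than the scatter, so the low numbers at this position do not belong to the 2-methylphenyl group alone. The new group also stands apart from the 4-fluorophenyl and 2,4-difluorophenyl groups, with a 3.0-fold lower number from compound 1 to compound 4 (0.47 log units; beyond the scatter) and a 4.7-fold lower number from compound 2 to compound 4 (0.67 log units; beyond the scatter) both beyond the scatter, which places compound 4 with compound 3 on the lower side of these four compounds. The two groups have the same count of heavy atoms but differ in make-up, one a ring of carbon only and the other a ring with a hetero atom, a chlorine and a hydrogen-bond acceptor, so among these compounds a ring of carbon only is not required for a number in this range.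

Nothing shown here accounts for how two such different groups come to read alike. Also open, going by these compounds, is how the number responds at this carbonyl carbon to a piperidine, a short alkyl chain or a phenyl ring bearing a carboxylic acid in place of these aryl groups.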